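Swapping the aryl group on the triazole amide

This account rests on a few compounds, and the source may have more. Where it says the series, first, only, none or still open, it means among the compounds named here.

In a functional assay on U-87MG ATCC cells (Homo sapiens) for cytotoxicity, read by MTT assay, with a stated time of 72 h (on this read-out higher numbers stand for weaker inhibition and lower numbers for stronger inhibition), compound 2 `COc1cc2c(Oc3ccc(NC(=O)c4nnn(-c5ccc(C)cc5)c4C(F)(F)F)cc3F)ccnc2cc1OCCCN1CCN(C)CC1` gives 2170 nM. Compound 1 `COc1cc2c(Oc3ccc(NC(=O)c4nnn(-c5ccc(F)c(F)c5)c4C(F)(F)F)cc3F)ccnc2cc1OCCCN1CCCCC1` gives 1210 nM in this assay, and the two numbers lie within the usual scatter of each other. Compound 3 `COc1cc2c(Oc3ccc(NC(=O)c4nnn(-c5ccc(F)c(F)c5)c4C(F)(F)F)cc3F)ccnc2cc1OCCCN1CCN(C)CC1` has not been measured. It differs from compound 2 by 3,4-difluorophenyl in place of 4-methylphenyl on an aromatic nitrogen. Compound 1 already carries this 3,4-difluorophenyl group, with a different amine at the chain end, and its value of 1210 nM sits close to compound 2, so the step is expected to be small. Compound 3 is expected to give 1400 nM, between 500 nM and 4000 nM. The expected step of a 1.6-fold lower number from compound 2 to compound 3 (0.19 log units; within the scatter) is a slight lowering, not beyond the scatter.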

Compound 3, half-maximal inhibitory concentration: 1390 nM
The estimate for compound 3 lay 1.0-fold (0.00 log units) above the measured number; low and high end bracket the measured number.
By their numbers in this assay, from the lowest: compounds 1, 3 and 2 (each within the scatter of the next).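

In this assay, the step of a 1.6-fold lower number from compound 2 to compound 3 (0.19 log units; within the scatter) shows that 3,4-difluorophenyl and 4-methylphenyl on this aromatic nitrogen cannot be told apart, even with the 4-methylpiperazin-1-yl end held fixed. Going by these compounds alone, compound 3 also allows a first comparison of the chain ends: the step of a 1.1-fold higher number from compound 1 to compound 3 (0.06 log units; within the scatter) shows that piperidin-1-yl and 4-methylpiperazin-1-yl cannot be told apart either. No measurement here offers an explanation for these two results.

From the compounds shown here alone, it remains open whether a carboxylic acid or a pyridine ring on this nitrogen would give a step beyond the scatter. The same question stands for dimethylamine at the chain end.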